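Swapping One Side Group on a Stable Compound

This account rests on a few compounds, and the source may have more. Where it says the series, first, only, none or still open, it means among the compounds named here.

Measured so far in an ADME assay on microsomes from liver (Homo sapiens) for metabolic stability; a higher number here means that more of the compound is left, a lower number that less of the compound is left:
Compound 1 `CCCCCOC(=O)N1CCN(C(=O)[C@H](CCC(=O)O)NC(=O)c2cc(N3CCC(OCCO)CC3)nc(-c3ccccc3)n2)CC1`: > 80%
Compound 2 `CCCCCOC(=O)N1CCN(C(=O)[C@H](CCC(=O)O)NC(=O)c2nc(-c3ccccc3)cc(N3CCC(CN)CC3)n2)CC1`: > 80%

Compound 1 gives > 80% in this assay, which is a limit of the assay and not an exact number. Compound 2 gives > 80%, which is also a limit. The data so far therefore show only (the limit of > 80% in this assay, at which 2 of the 2 values shown sit), and no order between the two compounds can be read from them.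

Compound 3 `CCCCCOC(=O)N1CCN(C(=O)[C@H](CCC(=O)O)NC(=O)c2cc(N3CCC(C(N)=O)CC3)nc(-c3ccccc3)n2)CC1` keeps the rest of compound 1 and changes one group, with carbamoyl in place of 2-hydroxyethoxy on a saturated ring carbon. Within the data shown here, no pair of measured compounds shows what this swap does, so any forecast is tentative. This expectation starts from compound 1, whose limit is > 80%. In this assay the estimated change is a step that the limit leaves unreadable from compound 1 to compound 3, which is expected to stay within the usual scatter and to have no clear direction. For compound 3 the estimated value is 83%, with an expected range from 68% to 95%.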

Compound 3, percent of the compound remaining: > 80%
Compound 3: only a limit was reported; the forecaster's own chance of this, stated with the estimate: 60%; the middle value lies beyond the limit too.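

Among these compounds, no step from compound 1 to compound 3 can be read, and neither its size nor its direction is known, because the values of both compounds are limits of the assay: the limit of > 80% in this assay, at which 3 of the 3 values shown sit. The compounds shown leave open how far each lies beyond that limit, and so what carbamoyl in place of 2-hydroxyethoxy does in this assay.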